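The source may report more compounds than this note shows. Statements on the series, on what has been measured and on what is new or still open speak of the compounds shown alone.

Measured compounds in this series:
compound 1, `Cc1cc(=O)oc2cc(Sc3cccc(Cl)n3)ccc12`: 920 nM
compound 2, `COC(=O)c1cccc(CSc2ccc3c(C)cc(=O)oc3c2)c1`: 5410 nM
compound 3, `CCc1cc(=O)c2ccc(Sc3cccc(Cl)[n+]3[O-])cc2o1`: > 29900 nM

In a functional assay on KBVIN cells (Homo sapiens) for antiproliferative activity, read by sulforhodamine B assay, with a stated time of 72 h (a higher number here means a weaker inhibitor of growth, a lower number a stronger inhibitor of growth), compound 1 gives 920 nM and compound 2 gives 5410 nM. For compound 3 only a limit is reported, > 29900 nM, and not a number. Compound 3 thus sits at the limit of > 29900 nM in this assay, at which 1 of the 3 values shown sits. Within the data shown here, no step between two measured compounds that differ in one place is available, so the compound 1 and compound 2 values are taken as they stand.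

Compound 4, `CCc1cc(=O)c2ccc(Sc3cccc(Cl)[n+]3[O-])c(C)c2o1`, differs from compound 3 by methyl in place of hydrogen on an aromatic carbon, a methyl in place of hydrogen on an aromatic carbon. Among the measured compounds shown here, no measured pair shows the effect of this change. Compound 4 is expected to remain near the limit, at about 30000 nM, within 10000 nM to 100000 nM. The expected step that the limit leaves unreadable from compound 3 to compound 4 is none beyond the scatter.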

Compound 4, concentration for 50% growth inhibition: > 28700 nM
Compound 4 was reported as a limit (the forecaster's own chance of this, stated with the estimate: 70%); the middle value lies beyond the limit too.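

No step can be read from compound 3 to compound 4: both stand only as limits in this assay. The compounds shown leave open what methyl in place of hydrogen on an aromatic carbon does to a measurable value.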